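Replacing a Carbamate on the Pyrrolidine Amide

The compounds below may be only part of what the source reports. "The series", "measured", "known", "first", "only" and "open" are said of these compounds alone.

Compound 2 `CC(C)(C)OC(=O)N1CCC[C@@H]1C(=O)N1CCC(NS(=O)(=O)c2cc(S(=O)(=O)c3ccccc3)ccc2C(F)(F)F)CC1` gives 210 nM in a functional assay on U2OS cells for antagonist activity at proto-oncogene Wnt-3 (Homo sapiens), read by a luciferase reporter, with a stated time of 18 h; a lower number here means that less compound is needed, a higher number that more compound is needed for the effect. Compound 1 `O=C(Cn1ccnc1)N1CCC(NS(=O)(=O)c2cc(S(=O)(=O)c3ccccc3)ccc2C(F)(F)F)CC1` gives 230 nM in this assay. The step of a 1.1-fold lower number from compound 1 to compound 2 (0.04 log units; within the scatter) lies within the scatter, so the two cannot be ranked. Compound 3 `CC(C)(C)CC(=O)N1CCC[C@H]1C(=O)N1CCC(NS(=O)(=O)c2cc(S(=O)(=O)c3ccccc3)ccc2C(F)(F)F)CC1` differs from compound 2 by 1-(neopentylcarbonyl)pyrrolidin-2-yl in place of 1-(tert-butoxycarbonyl)pyrrolidin-2-yl on a carbonyl carbon. Among the measured compounds shown here, only one measured step touches this carbonyl carbon, a 1.1-fold lower number from compound 1 to compound 2 (0.04 log units; within the scatter), and it stayed within the scatter despite a larger exchange. Compound 3 is therefore expected to show a step of no change at the digits printed from compound 2 to compound 3 (within the scatter), nothing beyond the scatter. Compound 3 is estimated at 210 nM, with a range from 80 nM to 550 nM.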

Compound 3, half-maximal effective concentration: 120 nM
Compound 3: middle estimate off by 1.8-fold (0.24 log units), on the high side, within the range that was stated.
By their numbers in this assay, from the lowest: compounds 3, 2 and 1 (each within the scatter of the next).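

With the neopentylcarbonyl group in place of the tert-butoxycarbonyl group, this assay gives a 1.8-fold lower number from compound 2 to compound 3 (0.24 log units; within the scatter), and the comparison with the imidazole compound gives a 1.9-fold lower number from compound 1 to compound 3 (0.28 log units; within the scatter). This carbonyl carbon has therefore now carried three different groups with all numbers within the scatter, including an exchange from 2 hydrogen-bond acceptors to 1 at the same 12 heavy atoms. Nothing measured here offers an explanation for these numbers. What the compounds shown leave open is how a primary amine or a carboxylic acid in place of the neopentyl group would read in this assay.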